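A few compounds are considered here, and "the series" means these few. Any claim that something is new, unique, unknown or untested is made for them only; others in the source may bear on it.

Measured so far:
compound 1, `Cc1[nH]n(-c2nc3c(C)cccc3[nH]2)c(=O)c1Cc1ccccc1`, in an assay on isolated protein for inhibition of alpha-ketoglutarate-dependent dioxygenase alkB homolog 3 (Homo sapiens), read by polymerase chain reaction, with a stated time of 1 h (a higher number here means a weaker inhibitor, a lower number a stronger inhibitor), gives 5900 nM
compound 2, `Cc1ccc2[nH]c(-n3[nH]c(C)c(Cc4ccc(-c5ccccc5)cc4)c3=O)nc2c1`, gives 5300 nM
compound 3, `Cc1[nH]n(-c2nc3c(C)cccc3[nH]2)c(=O)c1C`, gives only a limit of the assay, > 10000 nM

Compound 1 carries the higher of the two numbers shown, but compound 2 sits within the scatter of it, so the two cannot be separated. Within the data shown here, for compound 3 the result is a limit, sitting at the limit of > 10000 nM in this assay, at which 1 of the 3 values shown sits; the only counted step is an at least 1.6-fold higher number from compound 1 to compound 3 (0.22 log units; that floor lies within the scatter), and its floor lies within the scatter, so it says little about size.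

Compound 4, `Cc1ccc2[nH]c(-n3[nH]c(C)c(Cc4ccccc4)c3=O)nc2c1C`, differs from compound 1 by methyl in place of hydrogen on an aromatic carbon. Among the measured compounds shown here, no measured step concerns this kind of change: the step from compound 1 to compound 3 alters a saturated chain carbon, and compound 2 differs from compound 1 in more than one place, so only its value can be compared. With nothing pointing either way, the expected step in this assay is none beyond the scatter, a 1.1-fold lower number from compound 1 to compound 4 (0.03 log units; within the scatter). Compound 4 is therefore estimated at 5500 nM, with a range from 2000 nM to 15000 nM.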

Compound 4, half-maximal inhibitory concentration: > 10000 nM
Compound 4: a limit, no number (the forecaster's own chance of this, stated with the estimate: 25%); middle value at least 1.8-fold (0.25 log units) away from the limit.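

In this assay, this is the only step among the compounds shown that alters an aromatic carbon of the core, here one ortho to a methyl group, and it is an at least 1.6-fold higher number from compound 1 to compound 4 (0.22 log units; that floor lies within the scatter). Compound 4 gives only a limit of the assay, > 10000 nM. The floor of the step lies within the scatter, so adding methyl here is not shown to raise the number beyond the scatter, though no gain appears either, and a second compound now sits at the same limit: the limit of > 10000 nM in this assay, at which 2 of the 4 values shown sit.

From the compounds shown here alone, the true number of compound 4 stays open, so it cannot be said whether methyl at this place changes the number little or much. Also open, going by these compounds, is how a methoxy group or an amine on the same aromatic carbon would read.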